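The source may report more compounds than this note shows. Statements on the series, on what has been measured and on what is new or still open speak of the compounds shown alone.

In a functional assay on a cell-free system (Platelet, plasma, Homo sapiens) for inhibition (on this read-out lower numbers stand for stronger inhibition and higher numbers for weaker inhibition), compound 1 `O=C(O)COC1CCN(CCN(C(=O)c2ccc(C(F)(F)F)cc2)c2ccc(Cl)cc2)CC1` gives > 10000 nM, which is a limit of the assay. Compound 2 `O=C(O)COC1CCN(CCN(C(=O)c2cccc(F)c2)c2ccc(Cl)cc2)CC1` reads 340 nM and compound 3 `O=C(O)COC1CCN(CCN(C(=O)c2cccc(Cl)c2)c2ccc(Cl)cc2)CC1` reads 350 nM, so these two stand together, with a 1.0-fold higher number from compound 2 to compound 3 (0.01 log units; within the scatter). Compound 4 `Cc1cccc(C(=O)N(CCN2CCC(OCC(=O)O)CC2)c2ccc(Cl)cc2)c1` follows from compound 3 through methyl in place of chloro on an aromatic carbon, meta to a large group. The nearest measured change is that chloro-for-fluoro step, which stayed within the scatter. The large steps, an at least 29-fold lower number from compound 1 to compound 2 (1.46 log units; beyond the scatter) and an at least 28-fold lower number from compound 1 to compound 3 (1.45 log units; beyond the scatter), replaced the whole 4-(trifluoromethyl)phenyl and bear on this change only loosely. No step beyond the scatter is therefore expected in this assay. The expected step is a 1.1-fold higher number from compound 3 to compound 4 (0.06 log units; within the scatter). The estimate for compound 4 is 400 nM, within a range of 160 nM to 1000 nM.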

Compound 4, half-maximal inhibitory concentration: 310 nM
Beside the measured number, compound 4's estimate is 1.3-fold (0.11 log units) above it, and the stated range covers the measured number.
By their numbers in this assay, from the lowest: compounds 4, 2 and 3 (each within the scatter of the next). At a limit, above all of these: compound 1.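

In this assay, the 3-methylphenyl group reads level with both halogen-bearing groups, a 1.1-fold lower number from compound 3 to compound 4 (0.05 log units; within the scatter) and a 1.1-fold lower number from compound 2 to compound 4 (0.04 log units; within the scatter), so at this place a carbon substituent serves as well as fluoro or chloro. Against the 4-(trifluoromethyl)phenyl group, the step stays large, an at least 32-fold lower number from compound 1 to compound 4 (1.50 log units; beyond the scatter). The number for compound 1 is a limit of the assay: the limit of > 10000 nM in this assay, at which 1 of the 4 values shown sits.

The compounds shown leave open whether a methoxy group, a hydroxyl or an amine in this place would read the same. They also leave open whether trifluoromethyl here would read like methyl and the halogens or like compound 1.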